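The compounds below may be only part of what the source reports. "The series", "measured", "known", "first", "only" and "open" are said of these compounds alone.

Within the data shown here, in an ADME assay on Vero cells (Chlorocebus sabaeus) for cytotoxicity, read by MTT assay, with a stated time of 72 h (on this read-out higher numbers stand for lower toxicity in this test and lower numbers for higher toxicity in this test), three compounds sharing one core have numbers so far. Compound 1 (`COc1c(N2C[C@H]3CCCN(C(=O)Cn4cc(CN5C(=O)/C(=N/O)c6cc(F)ccc65)nn4)[C@H]3C2)c(F)cc2c(=O)c(C(=O)O)cn(C3CC3)c12`) gives 16 ug/mL and compound 2 (`CO/N=C1/C(=O)N(Cc2cn(CC(=O)N3CCC[C@@H]4CN(c5c(F)cc6c(=O)c(C(=O)O)cn(C7CC7)c6c5OC)C[C@@H]43)nn2)c2ccccc21`) gives 128 ug/mL while compound 3 (`CO/N=C1/C(=O)N(Cc2cn(CC(=O)N3CCC[C@@H]4CN(c5c(F)cc6c(=O)c(C(=O)O)cn(C7CC7)c6c5OC)C[C@@H]43)nn2)c2ccc(F)cc21`) gives 32 ug/mL on the same read-out. Compound 3 therefore lies within the scatter of compound 1 and clearly under compound 2. The next compound, compound 4 (`CO/N=C1/C(=O)N(Cc2cn(CC(=O)N3CCC[C@@H]4CN(c5c(F)cc6c(=O)c(C(=O)O)cn(C7CC7)c6c5OC)C[C@@H]43)nn2)c2ccc(C)cc21`), carries methyl in place of fluoro on an aromatic carbon and has not yet been measured. The step that bears most directly on it is fluoro in place of hydrogen on that same aromatic carbon, which gave a 4.0-fold lower number from compound 2 to compound 3 (0.60 log units; beyond the scatter) and counts as modest. The other step, methyl in place of hydrogen on an oxygen, gave a 2.0-fold higher number from compound 1 to compound 3 (0.30 log units; within the scatter) and says little about this change. Among the measured compounds shown here, no compound with methyl on that carbon has been measured, so the comparison remains indirect. Compound 4 loses the fluoro, so a partial return towards compound 2 at 128 ug/mL is expected, though not all the way. The estimated step is a 2.0-fold higher number from compound 3 to compound 4 (0.30 log units; within the scatter) and its expected direction is upward. For compound 4 the estimated value is 64 ug/mL with an expected range from 20 ug/mL to 160 ug/mL on this read-out.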

Compound 4, half-maximal cytotoxic concentration: 64 ug/mL
For compound 4 middle estimate and measured number coincide at the digits printed; the measured number falls inside the stated range.
By their numbers in this assay, from the lowest: compounds 1, 3, 4 and 2 (each within the scatter of the next, the first and the last beyond it).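

In this assay, among these compounds, this aromatic carbon had so far been read only for hydrogen against fluoro, with a 4.0-fold lower number from compound 2 to compound 3 (0.60 log units; beyond the scatter) as the one step, and that step left open how a carbon-based group would fall. Methyl now supplies two further steps at the same carbon, a 2.0-fold higher number from compound 3 to compound 4 (0.30 log units; within the scatter) when it replaces fluoro and a 2.0-fold lower number from compound 2 to compound 4 (0.30 log units; within the scatter) when it replaces hydrogen, so methyl cannot be told apart from either group in this test, although those two are told apart from each other. No measurement is available that would explain these numbers.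

The compounds shown carry only hydrogen, fluoro and methyl at this carbon, so it remains open how an amine, a carboxylic acid or a longer chain such as ethyl would read there. Going by these compounds, it is also open whether methyl at this carbon would read the same with hydrogen in place of methyl on the oxygen, the form that compound 1 carries alongside its fluoro.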